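Aryl ether in place of ester on the shared core

The source may hold more compounds than are shown below. What is called first, only, known or untested is meant among the compounds shown, and "the series" means these compounds.

Of the compounds shown here, three built on one shared core have been measured in a functional assay on HeLa cells (Homo sapiens) for cytotoxicity; on this read-out higher numbers stand for weaker inhibition and lower numbers for stronger inhibition. Compound 1 `CCCOC1=CC(=O)c2ccccc2C1=O` gives 51600 nM. Compound 2 `O=C(OC1=CC(=O)c2ccccc2C1=O)c1ccccc1` gives 55000 nM, and compound 3 `CC(=O)OC1=CC(=O)c2ccccc2C1=O` gives 62100 nM. Compound 3 carries the highest of the three numbers, yet both steps towards it, a 1.2-fold higher number from compound 1 to compound 3 (0.08 log units; within the scatter) and a 1.1-fold higher number from compound 2 to compound 3 (0.05 log units; within the scatter), lie within the scatter, so no ordering of the three can be claimed.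

Compound 4 `O=C1C=C(Oc2cccs2)C(=O)c2ccccc21` has not been measured. It differs from compound 3 by thiophen-2-yl in place of acetyl on an oxygen on an unsaturated carbon. Among the measured compounds shown here, no measured step exchanges an acetyl for an aromatic ring on the oxygen on the unsaturated carbon. The closest guides are the step on that same oxygen, a 1.2-fold higher number from compound 1 to compound 3 (0.08 log units; within the scatter), and the step on the carbonyl carbon, a 1.1-fold higher number from compound 2 to compound 3 (0.05 log units; within the scatter), both within the scatter. Every variation seen so far has left the number essentially unchanged. Compound 4 is therefore expected to stay in the same range, with an expected step of a 1.2-fold lower number from compound 3 to compound 4 (0.08 log units; within the scatter). The estimate for compound 4 in this assay is 52000 nM, within a range from 20000 nM to 140000 nM.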

Compound 4, half-maximal inhibitory concentration: 35300 nM
Estimate against measurement, compound 4: 1.5-fold (0.17 log units) above; low and high end bracket the measured number.
By their numbers in this assay, from the lowest: compounds 4, 1, 2 and 3 (each within the scatter of the next).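

In this assay, among the compounds shown here, the oxygen on an unsaturated carbon now carries an aromatic ring directly, which none of the earlier compounds had, and thiophen-2-yl in place of acetyl gives a 1.8-fold lower number from compound 3 to compound 4 (0.25 log units; within the scatter). Thiophen-2-yl in place of propyl gives a 1.5-fold lower number from compound 1 to compound 4 (0.16 log units; within the scatter), so this exchange also leaves the number within the scatter. Even this larger change, with one five-membered aromatic ring entering, has not moved the number beyond the scatter, and no supporting evidence bears on this result.

The compounds shown leave open whether a longer chain on this oxygen, or an amine or a carboxylic acid carried by the group there, would move the number beyond the scatter. They also leave open whether a phenyl ring directly on this oxygen would behave as thiophen-2-yl does.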